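The source may hold more compounds than are shown below. What is called first, only, known or untested is meant among the compounds shown, and "the series" means these compounds.

Working notes on the series, read in an ADME assay on HEK293 cells (Homo sapiens) for cytotoxicity, read by resazurin assay, with a stated time of 24 h; a lower number here means that less compound is tolerated, a higher number that more compound is tolerated. Compound 1 `COc1cc(O)c(C(=O)O)c(C=Cc2ccc3ccccc3c2)c1` gives 65000 nM. Compound 3 `O=C(O)c1c(O)cc(Cl)cc1CCc1ccc2ccccc2c1` gives 35000 nM, and these two numbers lie within the scatter of each other. Compound 2 `COc1cc(C=Cc2ccc3ccccc3c2)c(C(=O)O)c(OC)c1` reads > 100000 nM, which is a limit of the assay.

The next change leads from compound 3 to compound 4 `COc1cc(O)c(C(=O)O)c(CCc2ccc3ccccc3c2)c1`: methoxy in place of chloro on an aromatic carbon. The new group sits on an aromatic carbon, para to a carboxy group and meta to a hydroxy group.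

Among the compounds with values here, no measured step covers methoxy in place of chloro. The nearest evidence is an at least 1.5-fold higher number from compound 1 to compound 2 (0.18 log units; that floor lies within the scatter), where methyl takes the place of hydrogen on an oxygen on an aromatic ring. That step rests on (the limit of > 100000 nM in this assay, at which 1 of the 3 values shown sits), so it gives only a floor, and the floor lies within the scatter. It is a different change at a different place, and it bears only loosely on this one. In this assay no step beyond the scatter is therefore expected, with at most a slight lean towards more compound being tolerated.

The expected change is a 1.6-fold higher number from compound 3 to compound 4 (0.20 log units; within the scatter), which would stay within the scatter. For compound 4 the estimated value is 55000 nM, with an expected range of 25000 nM to 100000 nM.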

Compound 4, half-maximal cytotoxic concentration: 65000 nM
Compound 4: middle estimate off by 1.2-fold (0.07 log units), on the low side; low and high end bracket the measured number.
By their numbers in this assay, from the lowest: compounds 3, 1 and 4 (each within the scatter of the next). At a limit, above all of these: compound 2.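

In this assay, within the data shown here, the position para to a carboxy group and meta to a hydroxy group now has its first reading: methoxy in place of chloro gives a 1.9-fold higher number from compound 3 to compound 4 (0.27 log units; within the scatter) and so leaves the number within the scatter at this place, which the earlier compounds, with no step at this position, could not show. The result also gives a first view of the link between the two aromatic parts, which carries a double bond in compound 1 and none in compound 4: compound 1 gives 65000 nM and compound 4 gives 65000 nM in the same assay. The data shown give no measured reason for the step from chloro to methoxy.

As far as these compounds go, whether an amine or a longer alkoxy chain at this position would also stay within the scatter remains open. Also open, from the compounds shown here alone, is how chloro in place of methoxy would read on the link with the double bond, as in the core of compound 1.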